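Methyl on the hydrazone amine nitrogen: expected outcome

The source may hold more compounds than are shown below. What is called first, only, known or untested is meant among the compounds shown, and "the series" means these compounds.

Measured compounds:
compound 1, `COc1ccc(/C(=N\OC(C)=O)c2ccc3c(ccn3C)c2)c(OC)c1OC`: 580 nM in a functional assay on HL-60 cells (Homo sapiens) for cytotoxicity, read by XTT assay, with a stated time of 72 h; a higher number here means a weaker inhibitor, a lower number a stronger inhibitor
compound 2, `COc1ccc(/C(=N\N)c2ccc3c(ccn3C)c2)c(OC)c1OC`: 2000 nM in this assay
compound 3, `CCn1ccc2cc(/C(=N/N)c3ccc(OC)c(OC)c3OC)ccc21`: 2000 nM in this assay

Compound 2 sits level with compound 3 at the digits given; together they carry the highest numbers of the three. Compound 1 is the only one that separates from them: the change from the acetoxy group to the amino group on the double-bonded nitrogen is read by a 3.4-fold higher number from compound 1 to compound 2 (0.54 log units; beyond the scatter). By contrast, the methyl in place of hydrogen on the saturated chain carbon bound to the aromatic nitrogen is read by no change at the digits printed from compound 2 to compound 3 (within the scatter).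

Compound 4, `CN/N=C(/c1ccc2c(ccn2C)c1)c1ccc(OC)c(OC)c1OC`, differs from compound 2 by methyl in place of hydrogen on an amine nitrogen.

Going by the values given here, two measured steps bear on this. The step from compound 1 to compound 2 shows that what sits on the double-bonded nitrogen can move the number modestly; the step from compound 2 to compound 3 shows that a single methyl added at another place leaves it unchanged. Among the compounds with values here, no measured step puts a substituent on the amine nitrogen itself, so there is no direct precedent. The amino group is retained with one methyl on it, a small change, and the expected step is a 1.1-fold lower number from compound 2 to compound 4 (0.05 log units; within the scatter), no change beyond the scatter. Compound 4 is therefore estimated at 1800 nM, with a range from 700 nM to 4500 nM.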

Compound 4, half-maximal inhibitory concentration: 1000 nM
Estimate against measurement, compound 4: 1.8-fold (0.26 log units) above; the measured number falls inside the stated range.
By their numbers in this assay, from the lowest: compounds 1, 4, 2 and 3 (each within the scatter of the next, the first and the last beyond it).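

In this assay, going by these compounds alone, the amine nitrogen whose other neighbour is the double-bonded nitrogen is the first place where substitution on the amino group itself can be read, and methyl in place of hydrogen there stays inside the scatter (a 2.0-fold lower number from compound 2 to compound 4 (0.30 log units; within the scatter)). Within the data shown here, the same methylamino group also stays inside the scatter when set against acetoxy on the double-bonded nitrogen (a 1.7-fold higher number from compound 1 to compound 4 (0.24 log units; within the scatter)), whereas the amino group of compound 2 separates from acetoxy (a 3.4-fold higher number from compound 1 to compound 2 (0.54 log units; beyond the scatter)), so methylamino does not reproduce the separation that the earlier compounds showed. Nothing available accounts for either reading, and the steps are recorded here only as numbers.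

With one methyl as the only substituent shown on this nitrogen, the steps give no trend, and a single small group cannot show how much this place tolerates. As far as these compounds go, whether dimethylamino, a longer chain such as propyl, or an acetyl group on the same nitrogen stays within the scatter of compound 2 or moves clearly away from it remains open.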